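The source may hold more compounds than are shown below. What is called first, only, known or untested is meant among the compounds shown, and "the series" means these compounds.

Compound 1 `Cc1ccc(C2CC(c3ccc(C)c(C)c3)=NN2C2=NC(=O)CS2)cc1` gives 384000 nM in an ADME assay on RAW264.7 cells (Mus musculus) for cytotoxicity, read by MTT assay, with a stated time of 24 h; on this read-out higher numbers stand for lower toxicity in this test and lower numbers for higher toxicity in this test; compound 2 `Cc1cccc(C2CC(c3ccc(C)c(C)c3)=NN2C2=NC(=O)CS2)c1` gives 237000 nM.

Among these two numbers, compound 1 stands highest, with compound 2 nearest at a 1.6-fold lower number from compound 1 to compound 2 (0.21 log units; within the scatter). Compound 3 `Cc1ccc(C2CC(c3ccc(Cl)c(Cl)c3)=NN2C2=NC(=O)CS2)cc1` differs from compound 1 by 3,4-dichlorophenyl in place of 3,4-dimethylphenyl on a carbon with a double bond to nitrogen. For the measured compounds named here, no measured step touches this change; the only step known, from compound 1 to compound 2, concerns a different group and is within the scatter. With nothing to point either way, compound 3 is expected to give about 300000 nM, from 120000 nM to 700000 nM, an expected step of a 1.3-fold lower number from compound 1 to compound 3 (0.11 log units; within the scatter), which is nothing beyond the scatter.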

Compound 3, half-maximal cytotoxic concentration: 279000 nM
The estimate for compound 3 lay 1.1-fold (0.03 log units) above the measured number, and the stated range covers the measured number.
By their numbers in this assay, from the lowest: compounds 2, 3 and 1 (each within the scatter of the next).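

In this assay, 3,4-dichlorophenyl in place of 3,4-dimethylphenyl gives a 1.4-fold lower number from compound 1 to compound 3 (0.14 log units; within the scatter). For the compounds shown here, this is the first look at the carbon with a double bond to nitrogen, and it shows that this exchange, with its equal count of heavy atoms, moves the number no further than the scatter. Nothing at hand explains the result. On these data alone, whether an amine or a carboxylic acid on the phenyl ring at this position would shift the number remains open. So does whether 3,4-dichlorophenyl would behave the same alongside the 3-methylphenyl group of compound 2.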